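A few compounds are considered here, and "the series" means these few. Any claim that something is new, unique, unknown or untested is made for them only; others in the source may bear on it.

Measured compounds in a functional assay on HepG2 cells (Homo sapiens) for inhibition, read by MTT assay, with a stated time of 72 h; on this read-out higher numbers stand for weaker inhibition and lower numbers for stronger inhibition:
compound 1 `COc1ccc(C(=O)OC2(C(=O)Nc3ccc([N+](=O)[O-])cc3)CCCCC2)cc1`: 57.1 nM
compound 2 `O=C(OC1(C(=O)Nc2ccc([N+](=O)[O-])cc2)CCCCC1)c1ccc(Br)cc1`: 284 nM
compound 3 `CC(=O)Oc1ccccc1C(=O)OC1(C(=O)Nc2ccc([N+](=O)[O-])cc2)CCCCC1`: 17.7 nM

Compound 2 gives the highest number of the three in this assay; the steps of a 5.0-fold higher number from compound 1 to compound 2 (0.70 log units; beyond the scatter) and a 16-fold lower number from compound 2 to compound 3 (1.21 log units; beyond the scatter) both lie beyond the scatter, so compound 2 is the weakest inhibitor here. Compound 4 `O=C(Nc1ccc([N+](=O)[O-])cc1)C1(O)CCCCC1` differs from compound 2 by hydrogen in place of (4-bromophenyl)carbonyl on an oxygen on a saturated carbon. The measured steps, a 5.0-fold higher number from compound 1 to compound 2 (0.70 log units; beyond the scatter), a 3.2-fold lower number from compound 1 to compound 3 (0.51 log units; beyond the scatter) and a 16-fold lower number from compound 2 to compound 3 (1.21 log units; beyond the scatter), each exchange one aromatic group for another on the ester carbonyl and were modest to large; none removes the ester entirely, so they bear only loosely on this change. Loss of the whole aromatic ester is expected to weaken inhibition, giving a higher number: a 7.0-fold higher number from compound 2 to compound 4 (0.85 log units; beyond the scatter) is the expected step. Compound 4 is estimated at 2000 nM, within 400 nM to 15000 nM.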

Compound 4, half-maximal inhibitory concentration: 648 nM
The estimate for compound 4 lay 3.1-fold (0.49 log units) above the measured number, within the range that was stated.
By their numbers in this assay, from the lowest: compound 3; then compound 1; then compound 2; then compound 4.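

In this assay the step of a 2.3-fold higher number from compound 2 to compound 4 (0.36 log units; beyond the scatter) is modest, so inhibition persists with no ester on this oxygen. The (4-bromophenyl)carbonyl group therefore adds little over the free hydroxyl, whereas compound 1 and compound 3 print lower numbers than compound 4, so the effect of acylating this oxygen depends on the aromatic group carried by the ester. Nothing available here explains this step.

Still open, as far as these compounds go, is whether a simple acetyl group, a methyl ether or a carbamate on this oxygen would match compound 3 or stay nearer compound 4.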